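A few compounds are considered here, and "the series" means these few. Any claim that something is new, unique, unknown or untested is made for them only; others in the source may bear on it.

In a functional assay on trachea (Cavia porcellus) (on this read-out lower numbers stand for stronger inhibition and higher numbers for weaker inhibition), compound 2 `CO[C@@]12CCN(Cc3ccccc3)C[C@H]1[C@H](c1ccc3ccccc3c1)C(C#N)=C(N)O2` gives 23400 nM and compound 1 `CCCN1CC[C@@]2(OC)OC(N)=C(C#N)[C@@H](c3ccc4ccccc4c3)[C@@H]2C1` gives 37100 nM, two numbers that sit within the scatter of each other, so neither stands apart; the step of a 1.6-fold lower number from compound 1 to compound 2 (0.20 log units; within the scatter) confirms this. Compound 3 `CO[C@@]12CCN(Cc3ccccc3)C[C@H]1[C@H](c1ccc(Cl)cc1)C(C#N)=C(N)O2` differs from compound 2 by 4-chlorophenyl in place of naphthalen-2-yl on a saturated ring carbon. Among the compounds with values here, no measured step touches this position, since the only recorded one alters the chain carbon bound to the amine nitrogen, so nothing in the data points to a shift beyond the scatter in this assay. Compound 3 is therefore expected near 25000 nM, within 7000 nM to 90000 nM, which amounts to a 1.1-fold higher number from compound 2 to compound 3 (0.03 log units; within the scatter).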

Compound 3, half-maximal inhibitory concentration: 18500 nM
The estimate for compound 3 lay 1.4-fold (0.13 log units) above the measured number, within the range that was stated.
By their numbers in this assay, from the lowest: compounds 3, 2 and 1 (each within the scatter of the next).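

In this assay, the change at this saturated ring carbon gives a 1.3-fold lower number from compound 2 to compound 3 (0.10 log units; within the scatter), so 4-chlorophenyl can replace naphthalen-2-yl with no shift beyond the scatter. One six-membered aromatic ring of carbon only thus serves here as well as two, a point the earlier step on the chain carbon could not show. No evidence on the reason for this is available.

On these data alone, it remains open whether a non-aromatic group at this carbon, such as cyclohexyl, or a carboxylic acid, would move the number beyond the scatter. As far as these compounds go, the effect of a pyridine ring there also remains unknown.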